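Para-halogen swap on the aryl imine of compound 1

The source may hold more compounds than are shown below. What is called first, only, known or untested is meant among the compounds shown, and "the series" means these compounds.

Compound 1, `COc1ccc(/C=C2/CN(C)/C(=N/c3ccc(F)cc3)S2)cc1`, gives in a functional assay on HCT-116 cells (Homo sapiens) for antiproliferative activity, read by MTT assay, with a stated time of 72 h (on this read-out higher numbers stand for weaker inhibition and lower numbers for stronger inhibition), a value of 10000 nM, the only numerical result in this small set. Compound 2, `COc1ccc(/C=C2\S/C(=N\c3cc(C(F)(F)F)cc(C(F)(F)F)c3)N(C)C2=O)cc1`, returns only a limit of the assay, > 100000 nM. Compound 3, `C=C1CN(C)/C(=N/c2ccccc2)S1`, likewise sits at a limit, > 100000 nM. Going by the values given here, two of the three results therefore rest at the limit of > 100000 nM in this assay, at which 2 of the 3 values shown sit, so compound 1 stands alone as the single measured number, and no step between measured compounds is available to calibrate the change to compound 4, `COc1ccc(/C=C2/CN(C)/C(=N/c3ccc(Br)cc3)S2)cc1`. The difference is bromo in place of fluoro on an aromatic carbon. Among the compounds with values here, with no comparable step to lean on, the expected step of a 1.4-fold lower number from compound 1 to compound 4 (0.15 log units; within the scatter) is small and within the usual scatter, in no clear direction. Compound 4 is estimated at 7000 nM, with a range from 1500 nM to 40000 nM.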

Compound 4, half-maximal inhibitory concentration: 8900 nM
Estimate against measurement, compound 4: 1.3-fold (0.10 log units) below; measured number inside the range.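

In this assay, going by these compounds alone, bromo in place of fluoro gives a 1.1-fold lower number from compound 1 to compound 4 (0.05 log units; within the scatter) and supplies the first readable step. The 4-fluorophenyl to 4-bromophenyl change, on an aromatic carbon para to a large group, therefore leaves the two values within the scatter for this one pair. No measured property accounts for this outcome.

Steps to the other two compounds cannot be read: the limit of > 100000 nM in this assay, at which 2 of the 4 values shown sit. As far as these compounds go, whether a chloro group, an amine or a carboxylic acid at this position would also stay within the scatter remains open.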